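The source may hold more compounds than are shown below. What is called first, only, known or untested is meant among the compounds shown, and "the series" means these compounds.

Of the compounds shown here, two have been measured in a functional assay (trachea) for antagonist activity, with Cavia porcellus as the target; a higher number here means a more potent compound, by a factor of ten per unit of this negative logarithm, a lower number a less potent compound. Compound 1 `CCCCOC(=O)Nc1ccc2cnn(Cc3ccc(-c4nn[nH]n4)cc3OC)c2c1` gives 7.1 in this assay. Compound 2 `COc1cc(C(=O)NS(=O)(=O)c2ccccc2Cl)ccc1Cn1ccc2ccc(NC(=O)CC3CCCC3)cc21` gives 9.8, the highest of the two numbers; the nearest is compound 1, which lies lower by an amount beyond the usual scatter. The account now follows the step from compound 2 to compound 3 `COc1cc(C(=O)NS(=O)(=O)c2ccc3ccccc3c2)ccc1Cn1ccc2ccc(NC(=O)CC3CCCC3)cc21`, which has not yet been measured in this assay. The change is naphthalen-2-yl in place of 2-chlorophenyl on a sulfonyl sulfur whose other neighbours are an amide-type nitrogen. Within the data shown here, no step between measured compounds is known that would anchor this exchange, so the expectation rests on compound 2 alone. The step from compound 2 to compound 3 is expected to be small, a number 0.30 log units lower from compound 2 to compound 3 (within the scatter), within or close to the scatter. Compound 3 is therefore estimated at 9.5 in this assay, with a range from 8.8 to 10.2.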

Compound 3, negative logarithm of the antagonist equilibrium constant: 8.3
The estimate for compound 3 lay 1.20 log units above the measured number; the whole stated range lies above it.
By their numbers in this assay, from the lowest: compound 1; then compound 3; then compound 2.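

The sulfonyl sulfur, whose other neighbours are an amide-type nitrogen, proves sensitive to the group it carries: in this assay, naphthalen-2-yl in place of 2-chlorophenyl gives a number 1.50 log units lower from compound 2 to compound 3 (beyond the scatter) and so costs clear potency. This single pair shows that the position does not accept every aromatic group equally, even though neither group has any hydrogen-bond donors or acceptors and neither carries a net charge. Nothing shown here accounts for the size of this step.

The exchange removes the chlorine and adds a second six-membered aromatic ring at once, so the pair cannot say which of the two matters. Going by these compounds, an unsubstituted phenyl or a naphthalen-1-yl on the same sulfur would bear on that, and whether the step holds on another core also remains open.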